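The source may hold more compounds than are shown below. What is called first, only, known or untested is meant among the compounds shown, and "the series" means these compounds.

Measured so far in a functional assay on B16 cells (Mus musculus) for cytotoxicity, read by MTT assay, with a stated time of 72 h; a higher number here means a weaker inhibitor, a lower number a stronger inhibitor:
compound 1 `COc1c(OCCCCN2CCN(C)CC2)cc(O)c2c(=O)cc(-c3ccc(C)cc3)oc12` gives 5430 nM
compound 2 `COc1ccccc1-c1cc(=O)c2c(O)cc(OCCCCN3CCN(C)CC3)c(OC)c2o1` gives 9300 nM

Among the compounds with values here, compound 2 holds the highest of the two numbers in this assay; its nearest neighbour is compound 1, and the one step in the set, a 1.7-fold higher number from compound 1 to compound 2 (0.23 log units; within the scatter), lies within the scatter, so the two cannot be ordered.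

Compound 3 `COc1c(OCCCCN2CCN(C)CC2)cc(O)c2c(=O)cc(-c3ccc(F)cc3Br)oc12` is not yet measured. It differs from compound 2 in one place: 2-bromo-4-fluorophenyl in place of 2-methoxyphenyl on an aromatic carbon. Within the data shown here, the only measured step that bears on this change is the exchange of one aryl group for another at the same place, a 1.7-fold higher number from compound 1 to compound 2 (0.23 log units; within the scatter), which stayed within the scatter. Among the measured compounds shown here, no measured compound carries a halogenated aryl at that place, so the direction of any effect of the bromine and fluorine is unknown. On that basis the step from compound 2 to compound 3 is expected to stay within the scatter, as a 1.2-fold lower number from compound 2 to compound 3 (0.09 log units; within the scatter). Compound 3 is therefore estimated at 7500 nM in this assay, with a range from 2500 nM to 22000 nM that allows for the untested halogen pattern.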

Compound 3, half-maximal inhibitory concentration: 3440 nM
Compound 3: the middle estimate sits 2.2-fold (0.34 log units) above what was measured; the measured number falls inside the stated range.
By their numbers in this assay, from the lowest: compounds 3, 1 and 2 (each within the scatter of the next, the first and the last beyond it).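

In this assay, exchanging one aryl group for another at this place next to the ring oxygen now produces a step beyond the scatter: with 2-bromo-4-fluorophenyl in place of 2-methoxyphenyl, the data show a 2.7-fold lower number from compound 2 to compound 3 (0.43 log units; beyond the scatter) and the size of this step is modest. The separation holds only against 2-methoxyphenyl, since the exchange of 4-methylphenyl for the same halogenated aryl gives a 1.6-fold lower number from compound 1 to compound 3 (0.20 log units; within the scatter) and leaves those two groups unordered, so the three aryl groups do not form a full ranking and only the two ends of the series can be told apart. Nothing available here gives a reason for the step seen with the halogenated aryl.

Still open, going by these compounds, is how the bromine and the fluorine each contribute, which a 2-bromophenyl or a 4-fluorophenyl group at this place would separate. Also open is whether a pyridyl ring at this place, or a carboxylic acid on the aryl group, would move the number further from those of the three compounds shown here.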